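The source may report more compounds than this note shows. Statements on the series, on what has been measured and on what is new or still open speak of the compounds shown alone.

Compound 1 `O=C(OC[C@H]1O[C@@H](OC[C@H](O)[C@@H](O)c2ccc(O)cc2)[C@H](O)[C@@H](O)[C@@H]1O)c1ccccc1` — > 10000 nM
Compound 2 `O=C(OC[C@H]1O[C@@H](OC[C@H]2O[C@@H](OCc3ccccc3)[C@H](O)[C@@H](O)[C@@H]2O)[C@H](O)[C@@H](O)[C@@H]1O)c1ccccc1` — > 10000 nM

In an ADME assay on HCT-8 cells (Homo sapiens) for cytotoxicity (on this read-out higher numbers stand for weaker inhibition and lower numbers for stronger inhibition), compound 1 returns only a limit, > 10000 nM. In this assay compound 2 likewise returns only a limit, > 10000 nM. Within the data shown here, compound 2 therefore stands at the edge of what this assay reports, and the same holds for every value so far (the limit of > 10000 nM in this assay, at which 2 of the 2 values shown sit). Compound 3 `O=C(OC[C@H]1O[C@@H](OC[C@H]2O[C@@H](OC(=O)c3ccccc3)[C@H](O)[C@@H](O)[C@@H]2O)[C@H](O)[C@@H](O)[C@@H]1O)c1ccccc1` differs from compound 2 in one place: benzoyl in place of benzyl on an oxygen on a saturated carbon. Among the measured compounds shown here, with no measured step of this kind to draw on, the step that the limit leaves unreadable from compound 2 to compound 3 is expected to be none beyond the scatter. Compound 3 is therefore estimated at 15000 nM, within 5000 nM to 50000 nM.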

Compound 3, half-maximal inhibitory concentration: > 10000 nM
Compound 3 ended at the assay's limit (the forecaster's own chance of this, stated with the estimate: 80%); the middle value is on the limit's open side.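

Among these compounds, compound 2 and compound 3 both return only a limit in this assay, so no step between them can be read. What remains open is how compound 1, compound 2 and compound 3 compare, as all the values shown sit at one limit: the limit of > 10000 nM in this assay, at which 3 of the 3 values shown sit.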